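Trading chloro for fluoro in a growth inhibitor

The source may report more compounds than this note shows. Statements on the series, on what has been measured and on what is new or still open speak of the compounds shown alone.

In a functional assay on HCT-116 cells (Homo sapiens) for antiproliferative activity (on this read-out lower numbers stand for stronger inhibition of growth and higher numbers for weaker inhibition of growth), compound 1 (`Oc1cc(-c2ccc3ccccc3c2)nc2ncccc12`) gives 3800 nM and compound 3 (`Cc1ccc2c(O)cc(-c3ccc4ccccc4c3)nc2n1`) gives 3980 nM on the same scale. Compound 2 (`Cc1cnc2[nH]c(-c3cccc(Cl)c3)cc(=O)c2c1`) gives 30.2 nM as the lowest of the three numbers, and its gaps to the other two lie well beyond the scatter. Compound 4 (`Cc1cnc2[nH]c(-c3cccc(F)c3)cc(=O)c2c1`) has not been measured yet. It differs from compound 2 by one swap (fluoro in place of chloro on an aromatic carbon), with fluoro in place of chloro on an aromatic carbon, meta to a large group.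

Within the data shown here, only one measured step joins two close relatives, namely a 1.0-fold higher number from compound 1 to compound 3 (0.02 log units; within the scatter) for methyl in place of hydrogen on an aromatic carbon. That step involves no halogen, so it offers only weak guidance. No measured pair shows what exchanging chloro for fluoro does in this assay among these compounds, so nothing points firmly up or down and the range must stay wide. No change beyond the scatter is therefore expected, and the estimated size is a 1.3-fold higher number from compound 2 to compound 4 (0.12 log units; within the scatter) for this swap. Compound 4 is estimated at 40 nM with an expected range from 12 nM to 130 nM for now.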

Compound 4, concentration for 50% growth inhibition: 24 nM
Compound 4: the middle estimate sits 1.7-fold (0.22 log units) above what was measured; the range from low to high includes it.
By their numbers in this assay, from the lowest: compounds 4 and 2 (each within the scatter of the next); then compounds 1 and 3 (each within the scatter of the next).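

Exchanging chloro for fluoro on this aromatic carbon, meta to a large group, gives a 1.3-fold lower number from compound 2 to compound 4 (0.10 log units; within the scatter) in this assay, so this read-out does not tell the two halogens apart at this position. Among these compounds, the earlier compounds could not show this: their only measured step was a methyl in place of a hydrogen on a different pair of compounds, and it involved no halogen. The position therefore accepts either halogen with no change beyond the scatter in this assay, although nothing measured here accounts for this match.

The compounds shown leave open whether any halogen is needed at this place, or whether a plain hydrogen, a methoxy group, an amine or a nitrile would give a similar number. Among the compounds shown here, they also leave open whether fluoro and chloro would match in the same way at other places on this ring, or on the core of compound 1, where the halogen swap has no measured pair to read.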